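Swapping an Oxazole for a Pyridine on the Amide Nitrogen

The source may hold more compounds than are shown below. What is called first, only, known or untested is meant among the compounds shown, and "the series" means these compounds.

Among the measured compounds shown here, compound 2 `Cc1ccc(OCC(=O)N(Cc2cccs2)c2ncco2)cc1` has the lowest number of the three measured so far: in an assay on HEK293 cells for agonist activity at transient receptor potential cation channel subfamily M member 8 (Homo sapiens), read by fluorescence and calcium flux, with a stated time of 15 min (a lower number here means that less compound is needed, a higher number that more compound is needed for the effect), compound 2 gives 0.3 nM. Its nearest neighbour is compound 1 `CCN(Cc1cccs1)C(=O)COc1ccc(C)cc1`, which in this assay gives 8 nM, and the furthest is compound 3 `CCCc1ccc(OCC(=O)N(CC)Cc2cccs2)cc1`, which in this assay gives 1810 nM. The step of a 27-fold lower number from compound 1 to compound 2 (1.43 log units; beyond the scatter) shows that an aromatic ring on the amide-type nitrogen in place of ethyl brings the number down a great deal. The step of a 230-fold higher number from compound 1 to compound 3 (2.35 log units; beyond the scatter) concerns a different place, the chain on the aromatic ring, and does not speak to the nitrogen substituent.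

Compound 4 `Cc1ccc(OCC(=O)N(Cc2cccs2)c2ccccn2)cc1` differs from compound 2 in one place: pyridin-2-yl in place of 1,3-oxazol-2-yl on an amide-type nitrogen. For the measured compounds named here, only the step from compound 1 to compound 2 bears on this change, and it tells that an aromatic ring at this nitrogen gives a lower number than ethyl; it does not tell which aromatic ring gives the lowest number. Since compound 4 keeps an aromatic ring there, the change is expected to be modest, with the number for compound 4 expected to rise a little, a 3.3-fold higher number from compound 2 to compound 4 (0.52 log units; beyond the scatter). Compound 4 is therefore estimated to give 1 nM in this assay, with a range from 0.2 nM to 6 nM.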

Compound 4, half-maximal effective concentration: 200 nM
Estimate against measurement, compound 4: 200-fold (2.30 log units) below, outside the stated range (above it).
By their numbers in this assay, from the lowest: compound 2; then compound 1; then compound 4; then compound 3.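

At this amide-type nitrogen, an aromatic ring does not by itself bring the number down in this assay. Pyridin-2-yl in place of 1,3-oxazol-2-yl gives a 670-fold higher number from compound 2 to compound 4 (2.82 log units; beyond the scatter), and pyridin-2-yl in place of ethyl gives a 25-fold higher number from compound 1 to compound 4 (1.40 log units; beyond the scatter), so this aromatic ring ends up with a higher number than the small open chain it replaces. With the rest of the molecule unchanged, the three groups at this nitrogen therefore run from 1,3-oxazol-2-yl through ethyl to pyridin-2-yl, from the lowest number to the highest, and the identity of the ring counts for far more than the mere presence of one.

Going by these compounds, whether the very low number belongs to 1,3-oxazol-2-yl alone or extends to other five-membered aromatic rings with 2 hetero atoms remains open, and a thiazol-2-yl, a phenyl or a longer chain at this nitrogen would help to separate ring size from the hetero atoms. The two rings differ in size and in their hetero atoms at once, and no measurement available here explains the gap between them.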